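Swapping Thiophen-2-yl for Thiophen-3-yl on the Shared Core

The source may report more compounds than this note shows. Statements on the series, on what has been measured and on what is new or still open speak of the compounds shown alone.

Measured in an ADME assay on MRC5 cells (Homo sapiens), read by MTT assay, with a stated time of 72 h; on this read-out lower numbers stand for stronger inhibition and higher numbers for weaker inhibition:
Compound 1 `Nc1nc2c(c(-c3ccoc3)cn2[C@@H]2O[C@H](CO)[C@@H](O)[C@H]2O)c(=O)[nH]1`: 86100 nM
Compound 2 `Nc1nc2c(c(-c3cccs3)cn2[C@@H]2O[C@H](CO)[C@@H](O)[C@H]2O)c(=O)[nH]1`: > 100000 nM

Compound 2 stands at a limit of this assay and not at a number (> 100000 nM). Compound 3 (`Nc1nc2c(c(-c3ccsc3)cn2[C@@H]2O[C@H](CO)[C@@H](O)[C@H]2O)c(=O)[nH]1`) carries thiophen-3-yl in place of thiophen-2-yl on an aromatic carbon. Among the compounds with values here, only one measured step bears on this change, and it concerns a different swap, thiophen-2-yl in place of furan-3-yl. That step (an at least 1.1-fold higher number from compound 1 to compound 2 (0.06 log units; that floor lies within the scatter)) has a floor within the scatter. No step beyond the scatter is therefore expected in this assay (an at least 1.1-fold lower number from compound 2 to compound 3 (0.04 log units; that floor lies within the scatter)). Compound 3 is estimated at 90000 nM (expected range 40000 nM to 120000 nM).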

Compound 3, half-maximal inhibitory concentration: > 100000 nM
Compound 3 was reported as a limit (the forecaster's own chance of this, stated with the estimate: 55%); middle value at least 1.1-fold (0.04 log units) away from the limit.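

In this assay, compound 3 proves to be a limit and not a number, so thiophen-3-yl at this position, like thiophen-2-yl, gives no value within the range of the assay. The step from compound 2 to compound 3 cannot be read, because both stand at that limit: the limit of > 100000 nM in this assay, at which 2 of the 3 values shown sit. Thiophen-3-yl in place of furan-3-yl gives an at least 1.1-fold higher number from compound 1 to compound 3 (0.06 log units; that floor lies within the scatter).

From the compounds shown here alone, whether the two thiophene attachments differ at all in this assay stays open. So does what an amine or a carboxylic acid on this aromatic carbon would give.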